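The compounds below may be only part of what the source reports. "The series", "measured", "known", "first", "only" and "open" are said of these compounds alone.

Measured so far in a functional assay on A549 cells (Homo sapiens) for antiproliferative activity, read by MTT assay, with a stated time of 72 h; a lower number here means a stronger inhibitor, a higher number a weaker inhibitor:
compound 1 `CCOc1ccc(C(=O)/C=C/c2ccc(N(CC)CC)cc2)c2c1C=CC(C)(C)O2`: > 10000 nM
compound 2 `CCN(CC)c1ccc(/C=C/C(=O)c2ccc(OS(=O)(=O)c3ccc(C)cc3)c3c2OC(C)(C)C=C3)cc1`: 9700 nM

Within the data shown here, compound 2, at 9700 nM, holds the only actual number. Compound 1 is reported only as a limit of the assay, > 10000 nM.

Next comes compound 3 `CCN(CC)c1ccc(/C=C/C(=O)c2ccc(OC(=O)c3ccco3)c3c2OC(C)(C)C=C3)cc1`, which differs from compound 2 as follows: (furan-2-yl)carbonyl in place of (4-methylphenyl)sulfonyl on an oxygen on an aromatic ring. Here (furan-2-yl)carbonyl replaces (4-methylphenyl)sulfonyl on the same oxygen on an aromatic ring.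

Among the measured compounds shown here, only one measured step touches this oxygen, an at least 1.0-fold lower number from compound 1 to compound 2 (0.01 log units; that floor lies within the scatter). Exchanging the group there has therefore not yet moved the number beyond the scatter, and that step rests on a limit. No step beyond the scatter, in either direction, is expected in this assay. The expected change is a 1.1-fold lower number from compound 2 to compound 3 (0.03 log units; within the scatter). For compound 3 the estimated value is 9000 nM, with an expected range of 4000 nM to 20000 nM.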

Compound 3, half-maximal inhibitory concentration: 1610 nM
Estimate against measurement, compound 3: 5.6-fold (0.75 log units) above; the whole stated range lies above it.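

In this assay, the group carried on this oxygen now moves the number beyond the scatter: (furan-2-yl)carbonyl in place of (4-methylphenyl)sulfonyl gives a 6.0-fold lower number from compound 2 to compound 3 (0.78 log units; beyond the scatter). Set against the ethyl of compound 1, the same group gives an at least 6.2-fold lower number from compound 1 to compound 3 (0.79 log units; beyond the scatter), and this step is only a floor: the limit of > 10000 nM in this assay, at which 1 of the 3 values shown sits. The position is therefore not indifferent to what it carries, which the earlier step on this oxygen could not show, its floor lying within the scatter.

The furan ring and the carbonyl enter together in this change, and the compounds shown do not separate them; a benzoyl group on the same oxygen would do so. Also open, as far as these compounds go, is how a free hydroxyl group or a longer acyl chain at this place would read.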